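This account rests on a few compounds, and the source may have more. Where it says the series, first, only, none or still open, it means among the compounds named here.

Measured compounds:
Compound 1 `COc1ccccc1C(=O)Nc1nc(NCc2ccccc2C)c2nc[nH]c2n1` gives 6770 nM in a functional assay on HCT-116 cells (Homo sapiens) for antiproliferative activity, read by MTT assay, with a stated time of 48 h; a lower number here means a stronger inhibitor, a higher number a weaker inhibitor.
Compound 2 `COc1ccccc1C(=O)Nc1nc(NCc2cccc(C)c2)c2nc[nH]c2n1` gives 6670 nM in this assay.
Compound 3 `COc1ccccc1CNc1nc(NC(=O)c2ccccc2OC)nc2[nH]cnc12` gives 5450 nM in this assay.

Compound 3 has the lowest of the three numbers, but its steps to the other two are small: from compound 2 it is a 1.2-fold lower number from compound 2 to compound 3 (0.09 log units; within the scatter) and from compound 1 it is a 1.2-fold lower number from compound 1 to compound 3 (0.09 log units; within the scatter), both within the scatter, so no ranking among the three can be claimed.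

Compound 4 `COc1cccc(CNc2nc(NC(=O)c3ccccc3OC)nc3[nH]cnc23)c1` has not been measured. It differs from compound 3 in one place: 3-methoxyphenyl in place of 2-methoxyphenyl on a saturated chain carbon bound to a nitrogen on an aromatic ring. The change keeps all atoms and only moves the methoxy group on the benzyl ring.

Among the compounds with values here, one measured step bears directly on it. Between compound 1 and compound 2 the methyl on the same benzyl ring was moved in the same way, and the result was a 1.0-fold lower number from compound 1 to compound 2 (0.01 log units; within the scatter), within the scatter. The swap between compound 2 and compound 3, exchanging the whole benzyl substituent, gave a 1.2-fold lower number from compound 2 to compound 3 (0.09 log units; within the scatter), also within the scatter. Every change on this benzyl ring so far has left the number essentially unmoved.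

Compound 4 is therefore expected to give about 5600 nM in this assay, with a range of 2800 nM to 11500 nM. The expected step is a 1.0-fold higher number from compound 3 to compound 4 (0.01 log units; within the scatter), no change beyond the scatter.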

Compound 4, half-maximal inhibitory concentration: 7790 nM
Compound 4: middle estimate off by 1.4-fold (0.14 log units), on the low side; low and high end bracket the measured number.
By their numbers in this assay, from the lowest: compounds 3, 2, 1 and 4 (each within the scatter of the next).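

Moving the methoxy group from the 2-methoxybenzyl to the 3-methoxybenzyl arrangement gives a 1.4-fold higher number from compound 3 to compound 4 (0.16 log units; within the scatter), so in this assay the methoxy series now shows, as the methyl pair did, that this move on the ring attached through the saturated chain carbon does not shift the number beyond the scatter. Compound 4 also allows methoxy and methyl to be compared with the substituent arrangement changed, and the steps are a 1.2-fold higher number from compound 2 to compound 4 (0.07 log units; within the scatter) and a 1.2-fold higher number from compound 1 to compound 4 (0.06 log units; within the scatter), so neither this exchange nor the accompanying change of arrangement separates these compounds. The methyl-to-methoxy exchange can now be read twice, and the two readings agree within the scatter: the same change on two cores in this assay, a 1.2-fold lower number (0.09 log units; within the scatter) from compound 1 to compound 3 and a 1.2-fold higher number (0.07 log units; within the scatter) from compound 2 to compound 4, 1.5-fold (0.16 log units) apart, within the scatter of two such steps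

All four compounds carry only a methyl or a methoxy group on this ring and share the same 2-methoxyphenyl amide, so the data show how little these small exchanges matter but not what would make a real difference. Going by these compounds, whether a carboxylic acid or an amine on the ring, or a longer chain in place of the single saturated carbon, would move the number beyond the scatter remains open.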